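Dropping a chloro group from a hydrazone antiproliferative

The compounds below may be only part of what the source reports. "The series", "measured", "known", "first", "only" and "open" are said of these compounds alone.

Measured compounds, each in a functional assay on CCRF-CEM cells (Homo sapiens) for antiproliferative activity, read by sulforhodamine B assay, with a stated time of 48 h; on this read-out higher numbers stand for lower toxicity in this test and lower numbers for higher toxicity in this test:
- compound 1, `COc1ccc(OC)c(/C=C/c2nnc(Nc3ccc(Cl)cc3)o2)c1`, reported only as a limit: > 100000 nM
- compound 2, `COc1ccc(OC)c(/C=C/C(=O)N/N=C/c2ccc(Cl)cc2)c1`, reported only as a limit: > 100000 nM

Compound 2 does not give a number in this assay; its result is a limit of the test, and it therefore cannot be placed above or below compound 1, whose result is likewise a limit. Within the data shown here, both values sit together at the limit of > 100000 nM in this assay, at which 2 of the 2 values shown sit, so there is no measured step between them from which a size or direction could be read.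

Compound 3, `COc1ccc(OC)c(/C=C/C(=O)N/N=C/c2ccccc2)c1`, differs from compound 2 by a single change: hydrogen in place of chloro on an aromatic carbon. Among the measured compounds shown here, no measured pair in this set shows what this kind of change does in this assay, so no step beyond the usual scatter is expected in either direction. Since compound 2 itself stands at the limit, compound 3 is expected to do the same, and the estimated step from compound 2 to compound 3 is a step that the limit leaves unreadable from compound 2 to compound 3. The estimate for compound 3 is therefore 150000 nM, with a range from 50000 nM to 500000 nM, most likely reported again only as a limit.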

Compound 3, concentration lethal to 50% of the cells: > 100000 nM
Compound 3 was reported as a limit; the forecaster's own chance of this, stated with the estimate: 80%; the middle value lies beyond the limit too.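

Compound 3, like compound 2, gives only a limit and not a number, so no step can be read from the change of 4-chlorophenyl to phenyl: the limit of > 100000 nM in this assay, at which 3 of the 3 values shown sit.

The compounds shown leave open whether this change has any effect at all, and which change to the shared core would give a measurable value.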